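A Smaller Amine on the Amide-Bound Carbon

This account rests on a few compounds, and the source may have more. Where it says the series, first, only, none or still open, it means among the compounds named here.

Within the data shown here, compound 2 `CCN(CC)CN1C(=O)/C(=N\c2nc3ccc(C)cc3s2)c2c(Cl)cccc21` holds the lowest of the two numbers measured so far. In a functional assay on MDA-MB-231 cells (Homo sapiens) for cytotoxicity, read by sulforhodamine B assay, with a stated time of 48 h (a lower number here means a stronger inhibitor of growth, a higher number a weaker inhibitor of growth), compound 2 gives 20400 nM, whereas compound 1 `Cc1ccc2nc(/N=C3\C(=O)N(CN(C)C)c4cccc(Br)c43)sc2c1` gives 49000 nM in this assay, a gap beyond the usual scatter; the two differ in more than one place, so only their two values can be set side by side. Compound 3 `Cc1ccc2nc(/N=C3\C(=O)N(CN(C)C)c4cccc(Cl)c43)sc2c1` has not yet been measured. It differs from compound 2 by dimethylamino in place of diethylamino on a saturated chain carbon bound to an amide-type nitrogen in a ring. Among the measured compounds shown here, no measured pair shows what this change does here, so no step size is known from the data. The change is small in the counted atoms, and the expectation is a step of modest size, most likely toward a somewhat higher number, near the edge of the scatter. Compound 3 is thus expected to give about 28000 nM in this assay, with a range from 11000 nM to 70000 nM, which would mean an estimated step of a 1.4-fold higher number from compound 2 to compound 3 (0.14 log units; within the scatter).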

Compound 3, concentration for 50% growth inhibition: 10900 nM
Compound 3: the middle estimate sits 2.6-fold (0.41 log units) above what was measured; measured number below the stated range.
By their numbers in this assay, from the lowest: compounds 3 and 2 (each within the scatter of the next); then compound 1.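

In this assay, among these compounds, the first step that can be read at this position is a 1.9-fold lower number from compound 2 to compound 3 (0.27 log units; within the scatter), so exchanging diethylamino for dimethylamino on the saturated chain carbon bound to the amide-type nitrogen does not separate the two compounds. The halogen on the aromatic carbon now has a step of its own: chloro in place of bromo gives a 4.5-fold lower number from compound 1 to compound 3 (0.65 log units; beyond the scatter), and of the two changes that set compound 1 apart from compound 2, only this one lies beyond the scatter. Nothing measured here explains either step.

The compounds shown leave open whether a ring amine such as morpholine or pyrrolidine would behave like the two open-chain amines on that carbon. They also leave open how fluoro, or a plain hydrogen, would compare with chloro and bromo on the aromatic carbon.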